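Series notes: sulfur-linked benzyl groups on the shared core

This account rests on a few compounds, and the source may have more. Where it says the series, first, only, none or still open, it means among the compounds named here.

Three compounds of the series carry a value in a functional assay on PC-9 cells (Homo sapiens) for inhibition, read by MTT assay, with a stated time of 72 h; on this read-out lower numbers stand for stronger inhibition and higher numbers for weaker inhibition. Compound 2 `Cc1cc(Nc2cc(-c3ccccc3)[nH]n2)n2nc(SCc3csc4ccccc34)nc2n1` gives 4420 nM in this assay, the lowest of the three numbers, though the gap to each of the others lies within the scatter. Compound 3 `Cc1cc(Nc2cc(-c3cccs3)[nH]n2)n2nc(SCc3ccc(Br)cc3)nc2n1` gives 4890 nM in this assay, and compound 1 `Cc1cc(Nc2ccn(Cc3cccc4ccccc34)n2)n2nc(SCc3ccc(Br)cc3)nc2n1` gives 5660 nM in this assay. Within the data shown here, compounds 1 and 3 differ from compound 2 in more than one place, so no single step is read from them.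

Compound 4 `Cc1cc(Nc2cc(-c3ccccc3)[nH]n2)n2nc(SCc3ccc(C(F)(F)F)cc3)nc2n1` has not been measured. It differs from compound 2 in one place: 4-(trifluoromethyl)phenyl in place of 1-benzothiophen-3-yl on a saturated chain carbon bound to a sulfur. The group that leaves holds 1 hydrogen-bond acceptor; the group that enters holds none. Cut one bond further out, the change reads (1-benzothiophen-3-yl)methyl to 4-(trifluoromethyl)benzyl.

Among the measured compounds shown here, with no step between measured compounds to lean on, and all three values of this assay lying within the scatter of one another, the step from compound 2 to compound 4 is expected to be small, a 1.1-fold higher number from compound 2 to compound 4 (0.05 log units; within the scatter), in either direction or none beyond the scatter. Compound 4 is estimated at 5000 nM in this assay, within a range of 2500 nM to 10000 nM.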

Compound 4, half-maximal inhibitory concentration: 4240 nM
Compound 4: the middle estimate sits 1.2-fold (0.07 log units) above what was measured, and the stated range covers the measured number.
By their numbers in this assay, from the lowest: compounds 4, 2, 3 and 1 (each within the scatter of the next).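

Among these compounds, at the saturated chain carbon bound to a sulfur, the first readable step in this assay is a 1.0-fold lower number from compound 2 to compound 4 (0.02 log units; within the scatter), so this position now has a direct comparison, and it does not separate 1-benzothiophen-3-yl from 4-(trifluoromethyl)phenyl. The change removes the five-membered aromatic ring with its sulfur and the hydrogen-bond acceptor counted there, and brings in three fluorines, yet the read-out stays within the scatter. No measured data bear on the reason for this outcome.

Among the compounds shown here, compounds 1 and 3 differ from compounds 2 and 4 in more than one place, so no step to them can be read. Going by these compounds, whether an amine or a carboxylic acid on the phenyl ring, or a longer chain on the sulfur, would move the number beyond the scatter remains open.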